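The source may hold more compounds than are shown below. What is called first, only, known or untested is meant among the compounds shown, and "the series" means these compounds.

Measured compounds in an ADME assay on HEK293 cells (Homo sapiens) for cytotoxicity, read by resazurin assay, with a stated time of 48 h; on this read-out higher numbers stand for lower toxicity in this test and lower numbers for higher toxicity in this test:
- compound 1 `COc1ccc(S(=O)(=O)Nc2ccc(-c3nc4ccccc4o3)cc2)cc1` gives > 100000 nM, a limit of this assay.
- compound 2 `COc1ccc(Cl)cc1S(=O)(=O)Nc1ccc(-c2nc3ccccc3o2)cc1` gives 75000 nM.
- compound 3 `Cc1cccc(S(=O)(=O)Nc2ccc(-c3nc4ccccc4o3)cc2)c1` gives > 100000 nM, a limit of this assay.

Compound 3 therefore stands at the limit rather than at a number, and it shares that position with one further compound, as the limit of > 100000 nM in this assay, at which 2 of the 3 values shown sit, records. Of the measured steps, an at least 1.3-fold lower number from compound 1 to compound 2 (0.12 log units; that floor lies within the scatter) and an at least 1.3-fold higher number from compound 2 to compound 3 (0.12 log units; that floor lies within the scatter) both sit within the scatter, and a step that the two limits leave unreadable from compound 1 to compound 3 cannot be read. All three measured compounds thus sit close together at the low-toxicity end of what this assay can report.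

The next compound, compound 4 `C=Cc1ccc(S(=O)(=O)Nc2ccc(-c3nc4ccccc4o3)cc2)cc1`, has not yet been measured in this assay. Compared with compound 3 the change is 4-vinylphenyl in place of 3-methylphenyl on a sulfonyl sulfur. Within the data shown here, the only measured steps that bear on it are those that also exchange one group on the sulfonyl sulfur, and none of them reached beyond the scatter. No step beyond the scatter is therefore expected in this assay, in either direction, and the most likely outcome is again a limit.

Compound 4 is expected to give about 100000 nM, within 40000 nM to 200000 nM. The expected step of a number no higher from compound 3 to compound 4 (the limit leaves the size open) is estimated to stay within the scatter.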

Compound 4, half-maximal cytotoxic concentration: > 100000 nM
Compound 4: only a limit was reported; the forecaster's own chance of this, stated with the estimate: 60%; the middle value lies on the limit itself.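

In this assay compound 4 gives > 100000 nM, which is a limit of the assay. Among these compounds, the one readable new step, an at least 1.3-fold higher number from compound 2 to compound 4 (0.12 log units; that floor lies within the scatter), does not carry the series beyond the scatter, and the other two new steps cannot be read. A 4-vinylphenyl on the sulfonyl sulfur, the first group in this set with a double bond outside an aromatic ring, thus gives no numeric value in this test, and the sulfonyl aryl changes shown so far mostly end at the same reporting limit: the limit of > 100000 nM in this assay, at which 3 of the 4 values shown sit.

How far the group on the sulfonyl sulfur can shift this read-out stays open, as compound 2 alone gives a number, 75000 nM, and no step shown reaches beyond the scatter. Also open, from the compounds shown here alone, is whether an amine or a carboxylic acid on that aromatic ring, a longer chain in place of the vinyl, or a change to the shared core would give a value clearly separated from the limit.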